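Aryl variation on the shared core: estimate for compound 3

The source may hold more compounds than are shown below. What is called first, only, known or untested is meant among the compounds shown, and "the series" means these compounds.

compound 1, `Cc1nc(-c2ccccc2)sc1COc1ccc(OCC(=O)O)c(F)c1`, 374 nM
compound 2, `Cc1nc(-c2ccc(F)cc2)sc1COc1ccc(OCC(=O)O)c(F)c1`, 112 nM

In an assay on CHO cells for agonist activity at Free fatty acid receptor 1 (Homo sapiens), read by FLIPR (a higher number here means that more compound is needed for the effect, a lower number that less compound is needed), compound 1 gives 374 nM, and compound 2 gives 112 nM. Among the compounds with values here, compound 2 has the lowest of the two numbers; the only measured step is a 3.3-fold lower number from compound 1 to compound 2 (0.52 log units; beyond the scatter). Compound 3, `Cc1cccc(-c2nc(C)c(COc3ccc(OCC(=O)O)c(F)c3)s2)c1`, differs from compound 2 in one place: 3-methylphenyl in place of 4-fluorophenyl on an aromatic carbon. Within the data shown here, no measured step bears directly on this change; the step of a 3.3-fold lower number from compound 1 to compound 2 (0.52 log units; beyond the scatter) concerns a different group on the same ring and does not fix the direction here. A step near the scatter, leaning toward a higher number, is expected: a 1.8-fold higher number from compound 2 to compound 3 (0.25 log units; within the scatter). For compound 3 in this assay the estimate is 200 nM, with a range of 70 nM to 600 nM.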

Compound 3, half-maximal effective concentration: 247 nM
The estimate for compound 3 lay 1.2-fold (0.09 log units) below the measured number; measured number inside the range.
By their numbers in this assay, from the lowest: compound 2; then compounds 3 and 1 (each within the scatter of the next).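

Carrying 3-methylphenyl instead of 4-fluorophenyl on this aromatic carbon, next to the ring nitrogen and the ring sulfur, gives a 2.2-fold higher number from compound 2 to compound 3 (0.34 log units; beyond the scatter) in this assay. The methyl in place of hydrogen gives a 1.5-fold lower number from compound 1 to compound 3 (0.18 log units; within the scatter), so this substitution does not separate compound 3 from compound 1. Among these three compounds, only 4-fluorophenyl stands beyond the scatter from both others.

From the compounds shown here alone, the pair of compound 2 and compound 3 changes both the group and where it sits on the aryl ring, leaving those two contributions unseparated, and an amine or a methoxy group on that ring remains open. No measurement shown offers an explanation for these steps.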